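The compounds below may be only part of what the source reports. "The series", "measured", "known", "first", "only" and "open" are said of these compounds alone.

In a functional assay on Huh-7 cells (Homo sapiens) for antiproliferative activity, read by sulforhodamine B assay, with a stated time of 72 h (a lower number here means a stronger inhibitor, a higher number a weaker inhibitor), compound 1, `N#Cc1cccc(COc2ccc(-c3cc(CN4CCN(Cc5ccc(C(F)(F)F)cc5)CC4)no3)cc2)c1`, gives 100 nM, the lowest of the two numbers recorded. Its closest neighbour is compound 2, `COc1cccc(COc2ccc(-c3cc(CN4CCN(Cc5ccc(C(F)(F)F)cc5)CC4)no3)cc2)c1`, which in this assay gives 800 nM; the step of an 8.0-fold higher number from compound 1 to compound 2 (0.90 log units; beyond the scatter) came from methoxy in place of cyano on an aromatic carbon. Compound 3, `N#Cc1cccc(COc2ccc(-c3cc(CN4CCN(c5ccc(C(F)(F)F)cc5)CC4)no3)cc2)c1`, has not yet been measured in this assay. It differs from compound 1 by 4-(trifluoromethyl)phenyl in place of 4-(trifluoromethyl)benzyl on an amine nitrogen in a ring. Within the data shown here, no measured step touches this part of the shared core: the only step recorded changes a group elsewhere, so it offers no direct guide. With nothing to anchor a direction, the expectation for compound 3 is a step of a 2.0-fold higher number from compound 1 to compound 3 (0.30 log units; within the scatter), with a wide range on either side. Compound 3 is therefore estimated to give 200 nM in this assay, between 50 nM and 800 nM.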

Compound 3, half-maximal inhibitory concentration: 2200 nM
Compound 3: middle estimate off by 11-fold (1.04 log units), on the low side, and the stated range ends below it.
By their numbers in this assay, from the lowest: compound 1; then compound 2; then compound 3.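

On paper the change is small: 4-(trifluoromethyl)benzyl and 4-(trifluoromethyl)phenyl both carry one six-membered aromatic ring of carbon only and no hydrogen-bond donors or acceptors. Even so, in this assay it gives a 22-fold higher number from compound 1 to compound 3 (1.34 log units; beyond the scatter), which is larger than the earlier change elsewhere in the molecule, an 8.0-fold higher number from compound 1 to compound 2 (0.90 log units; beyond the scatter), so activity here depends strongly on which of these two groups sits on this ring nitrogen. Nothing measured here explains why the number rises so far.

The compounds shown leave open how activity responds to a longer chain on this nitrogen, such as 2-phenylethyl, or to a benzoyl group with a carbonyl on the nitrogen. They also do not show whether the trifluoromethyl group matters, as a plain benzyl group would test.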